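From compound 3 to compound 4: another phenyl exchange

The source may hold more compounds than are shown below. What is called first, only, known or untested is meant among the compounds shown, and "the series" means these compounds.

Measured in a functional assay on Jurkat cells (Homo sapiens); a higher number here means a weaker inhibitor, a lower number a stronger inhibitor:
- compound 1 `CC(C)[C@H](NC(=O)COc1cccc2ccccc12)C(=O)N[C@@H](CC(=O)O)C(=O)COc1cc(F)cc(F)c1F`: 30000 nM
- compound 2 `CC(C)[C@H](NC(=O)COc1cccc2ccccc12)C(=O)N[C@@H](CC(=O)O)C(=O)COc1cc(F)c(F)cc1F`: 39300 nM
- compound 3 `CC(C)[C@H](NC(=O)COc1cccc2ccccc12)C(=O)N[C@@H](CC(=O)O)C(=O)COc1cccc(C(F)(F)F)c1F`: 50400 nM

Compound 3, at 50400 nM, cannot be separated from the other two compounds: a 1.3-fold higher number from compound 2 to compound 3 (0.11 log units; within the scatter) and a 1.7-fold higher number from compound 1 to compound 3 (0.23 log units; within the scatter). The next compound, compound 4 `CC(C)[C@H](NC(=O)COc1cccc2ccccc12)C(=O)N[C@@H](CC(=O)O)C(=O)COc1ccc([N+](=O)[O-])cc1F`, has 2-fluoro-4-nitrophenyl in place of 2-fluoro-3-(trifluoromethyl)phenyl on an oxygen on a saturated carbon.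

All three measured steps exchange the group at this same place, so they are the closest guide. Besides the two above, there is a 1.3-fold higher number from compound 1 to compound 2 (0.12 log units; within the scatter), and none of the three leaves the scatter. However, no measured compound carries the 2-fluoro-4-nitrophenyl group, so the guide is only indirect.

The expected change is a 1.3-fold lower number from compound 3 to compound 4 (0.12 log units; within the scatter), and no step beyond the scatter is anticipated in either direction. For compound 4 the estimated value is 38000 nM, with an expected range of 15000 nM to 90000 nM.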

Compound 4, half-maximal inhibitory concentration: 30300 nM
For compound 4 the middle estimate is 1.3-fold (0.10 log units) above the measured one, within the range that was stated.
By their numbers in this assay, from the lowest: compounds 1, 4, 2 and 3 (each within the scatter of the next).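

In this assay the 2-fluoro-4-nitrophenyl group brings nitrogen, oxygen and hydrogen-bond acceptors that the 2-fluoro-3-(trifluoromethyl)phenyl group lacks, yet the number stays within the scatter (a 1.7-fold lower number from compound 3 to compound 4 (0.22 log units; within the scatter)). It also stays within the scatter of the two trifluorophenyl compounds (a 1.3-fold lower number from compound 2 to compound 4 (0.11 log units; within the scatter); a 1.0-fold higher number from compound 1 to compound 4 (0.00 log units; within the scatter)), so across these four compounds no exchange at this place, on an oxygen on a saturated carbon, has moved the number beyond the scatter, even with a substituent that is not a halogen-bearing group. Nothing available explains this lack of movement.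

As far as these compounds go, whether an amine or a carboxylic acid on the phenyl ring, or a saturated alkyl chain in place of the phenyl, would move the number beyond the scatter remains open. Also open, from the compounds shown here alone, is whether any change elsewhere in the shared core would do so.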